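Replacing the 2-acetoxypropyl Group of Compound 2

A few compounds are considered here, and "the series" means these few. Any claim that something is new, unique, unknown or untested is made for them only; others in the source may bear on it.

In a functional assay on HeLa cells (Homo sapiens) for cytotoxicity, read by MTT assay (on this read-out lower numbers stand for stronger inhibition and higher numbers for weaker inhibition), compound 1 (`COCCO[C@H](CC=C(C)C)C1=CC(=O)c2c(O)ccc(O)c2C1=O`) gives 62400 nM and compound 2 (`CC(=O)OC(C)CO[C@H](CC=C(C)C)C1=CC(=O)c2c(O)ccc(O)c2C1=O`) gives 40100 nM. Among the measured compounds shown here, these two numbers lie within the scatter of each other, so compound 2 stands level with the only other compound measured, and the two cannot be ranked.

Compound 3 (`CC(C)=CC[C@@H](OC(=O)C1CCCCO1)C1=CC(=O)c2c(O)ccc(O)c2C1=O`) keeps the shared core but carries (oxan-2-yl)carbonyl in place of 2-acetoxypropyl on an oxygen on a saturated carbon.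

For the measured compounds named here, only one measured step bears on this change: a 1.6-fold lower number from compound 1 to compound 2 (0.19 log units; within the scatter). That step also alters the group reached through this oxygen, and it stays within the scatter. Going by the values given here, it is weak guidance, however, as no measured compound carries the (oxan-2-yl)carbonyl group. From the compounds shown here alone, no step beyond the scatter is therefore expected in this assay, and the direction remains open, with only a slight lean towards a lower number. The expected size is a 1.4-fold lower number from compound 2 to compound 3 (0.16 log units; within the scatter). For compound 3 the estimated value is 28000 nM, with an expected range of 8000 nM to 75000 nM.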

Compound 3, half-maximal inhibitory concentration: > 100000 nM
Compound 3 was reported as a limit; the forecaster's own chance of this, stated with the estimate: 8%; middle value at least 3.5-fold (0.55 log units) away from the limit.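

In this assay compound 3 gives > 100000 nM, a limit of the assay and not a number, and it is the only compound shown that reaches this limit: the limit of > 100000 nM in this assay, at which 1 of the 3 values shown sits.

This position therefore responds to the group on its oxygen, which the earlier pair could not show, since a 1.6-fold lower number from compound 1 to compound 2 (0.19 log units; within the scatter); swapping the open 2-acetoxypropyl chain for (oxan-2-yl)carbonyl, with its six-membered non-aromatic ring, gives an at least 2.4-fold higher number from compound 2 to compound 3 (0.39 log units; beyond the scatter). The comparison with the 2-methoxyethyl compound is less firm, as the listed step reads an at least 1.6-fold higher number from compound 1 to compound 3 (0.20 log units; that floor lies within the scatter), so on this floor alone the two cannot be ranked.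

From the compounds shown here alone, how far the true value of compound 3 lies past the limit remains unknown, so the size of the change is known only as a floor. The compounds shown also leave open whether the ring or the carbonyl bound directly to this oxygen accounts for the step, and what a plain acetyl group, an open-chain acyl group of similar length or a chain ending in an amine would give here.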